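The compounds below may be only part of what the source reports. "The series", "measured", "known", "first", "only" and "open" are said of these compounds alone.

Compound 3 `CC(C)C1NC(=O)N(C2CCCCC2)C1=O` and compound 1 `CCC(C)C1NC(=O)N(C2CCCCC2)C1=O` share one core. In a functional assay on CCRF-CEM cells (Homo sapiens) for inhibition (on this read-out lower numbers stand for stronger inhibition and higher numbers for weaker inhibition), compound 3 gives only a limit, > 200000 nM. Compound 1 likewise gives only a limit in this assay, > 200000 nM. Their change, (methyl in place of hydrogen on a saturated chain carbon, two bonds along the chain from a saturated ring carbon), leaves a step whose size cannot be read, a step that the two limits leave unreadable from compound 3 to compound 1, because both values sit at the limit of > 200000 nM in this assay, at which 3 of the 3 values shown sit. Compound 2 `CC(C)C(NC(=O)n1nnc2ccccc21)C(=O)NC1CCCC1` has another core; the difference between the two cores is not broken down here. In this assay compound 2 also gives only a limit, > 200000 nM. Compound 4 `CCC(C)C(NC(=O)n1nnc2ccccc21)C(=O)NC1CCCC1` arises from compound 2 by methyl in place of hydrogen on a saturated chain carbon, three bonds along the chain from an amide-type nitrogen and a carbonyl carbon, the same kind of change as before, though its surroundings differ: earlier two bonds along the chain from a saturated ring carbon, here three bonds along the chain from an amide-type nitrogen and a carbonyl carbon. Compound 4 is expected to give only a limit again, a step of a number no higher from compound 2 to compound 4 (the limit leaves the size open), because compound 2 sits at the limit of > 200000 nM in this assay, at which 3 of the 3 values shown sit. Compound 4 is therefore estimated at 200000 nM, between 100000 nM and 600000 nM.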

Compound 4, half-maximal inhibitory concentration: 116000 nM
Compound 4: middle estimate off by 1.7-fold (0.24 log units), on the high side; the measured number falls inside the stated range.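

In this assay, the change of isopropyl to sec-butyl gives an at least 1.7-fold lower number from compound 2 to compound 4 (0.23 log units; that floor lies within the scatter). This is only a floor, as the value of compound 2 is a limit, so the real step may be larger, but the data do not establish a real gain. The same kind of change from compound 3 to compound 1 cannot be read, so nothing shows whether the change carries from one core to the other, because most values shown sit at one limit: the limit of > 200000 nM in this assay, at which 3 of the 4 values shown sit.

On these data alone, it remains open whether a longer chain, an amine or a carboxylic acid on that saturated chain carbon would lower the number on either core. As far as these compounds go, it also remains open whether the core of compound 1 can give a readable number at all.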